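The source may hold more compounds than are shown below. What is called first, only, known or untested is meant among the compounds shown, and "the series" means these compounds.

Compound 1, `COc1ccc(-c2cc(=O)c3c(OC)cc(OC)cc3n2C)cc1`, and compound 2, `COc1ccc(-c2cc(=O)c3c(OC)cc(OC)cc3n2S(=O)(=O)c2ccc(C#N)cc2)cc1`, share one core and differ only on an aromatic nitrogen, where compound 2 carries a (4-cyanophenyl)sulfonyl group in place of the methyl of compound 1. In an ADME assay on BJ cells (Homo sapiens) for antiproliferative activity, with a stated time of 72 h (a higher number here means that more compound is needed for the effect, a lower number that less compound is needed), compound 1 gives 68000 nM. For compound 2, this assay reports only a limit, > 17200 nM, so its true value is not known. The step that the limit leaves unreadable from compound 1 to compound 2 therefore cannot be read, as the limit of > 17200 nM in this assay, at which 1 of the 2 values shown sits, shows. Compound 3, `COc1ccc(-c2cc(=O)c3c(OC)cc(OC)cc3n2S(=O)(=O)c2ccc(Cl)cc2)cc1`, is the next member and differs from compound 2 by chloro in place of cyano on an aromatic carbon. Among the measured compounds shown here, no measured pair exchanges one substituent for another on that outer aromatic ring, so nothing among the measured steps bears directly on this change. Since compound 2 is known only as a limit, compound 3 is expected to sit in the same region, and the step that the limit leaves unreadable from compound 2 to compound 3 is expected to stay within the usual scatter of repeated measurements. Compound 3 is therefore estimated at 30000 nM in this assay, with a plausible range from 10000 nM to 100000 nM, and a fair chance that only a limit is returned again.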

Compound 3, half-maximal effective concentration: > 34400 nM
Compound 3 ended at the assay's limit; the forecaster's own chance of this, stated with the estimate: 65%; at least 1.1-fold (0.05 log units) between middle value and limit.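

On these data alone, compound 3 returns only a limit, so its true value stays unknown: the limit of > 34400 nM in this assay, at which 1 of the 3 values shown sits. Among the compounds shown here, no step among compound 1, compound 2 and compound 3 can therefore be read. The compounds shown leave open whether chloro in place of cyano, or either sulfonyl group in place of methyl, changes the concentration needed in this assay.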